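This account rests on a few compounds, and the source may have more. Where it says the series, first, only, none or still open, it means among the compounds named here.

Measured compounds in the series:

compound 1 `CC1CCN(S(=O)(=O)N2CCN(CC(=O)Nc3cc(Cl)ccc3OC(C)C)CC2)CC1`: 5100 nM
compound 2 `COc1ccc(Cl)cc1NC(=O)[C@H](C)N1CCN(S(=O)(=O)N2CCC(C)CC2)CC1`: 4400 nM
compound 3 `COc1ccc(Cl)cc1NC(=O)CN1CCN(S(=O)(=O)N2CCC(C)CC2)[C@@H](C)C1`: reported only as a limit, > 10000 nM

All three were run in an assay on HEK293 cells for inhibition of potassium channel subfamily T member 1 (Homo sapiens), read by thallium flux; on this read-out higher numbers stand for weaker inhibition and lower numbers for stronger inhibition. Compound 1 and compound 2 sit within the usual scatter of each other, so the two cannot be ranked. Compound 3 gives no number at all; its result is the limit of > 10000 nM in this assay, at which 1 of the 3 values shown sits. Between compound 1 and compound 2 two places differ at once, and compound 3 differs from both in another way, so no single-point step can be read off among the measured compounds.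

The next compound, compound 4 `CC1CCN(S(=O)(=O)N2CCN(CC(=O)Nc3cc(Cl)ccc3OCC3CC3)CC2)CC1`, differs from compound 1 in one place: cyclopropylmethyl in place of isopropyl on an oxygen on an aromatic ring. The shared core, the amide, the sulfonamide and the substituted aromatic ring are otherwise kept. Within the data shown here, nothing among the measured compounds shows what an exchange at this oxygen does, so the expectation rests on the small size of the change alone: a step of no more than the scatter, in no particular direction. The step from compound 1 is expected to be a 1.1-fold lower number from compound 1 to compound 4 (0.05 log units; within the scatter). Compound 4 is expected to give about 4500 nM in this assay, within a range from 1800 nM to 11000 nM.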

Compound 4, half-maximal inhibitory concentration: 7500 nM
Beside the measured number, compound 4's estimate is 1.7-fold (0.22 log units) below it; low and high end bracket the measured number.
By their numbers in this assay, from the lowest: compounds 2, 1 and 4 (each within the scatter of the next). At a limit, above all of these: compound 3.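

The exchange of isopropyl for cyclopropylmethyl on an oxygen on an aromatic ring gives the series its first single-place step, and in this assay it reads as a 1.5-fold higher number from compound 1 to compound 4 (0.17 log units; within the scatter). Compound 1 and compound 4 therefore cannot be told apart, so bringing a three-membered ring to this oxygen gives no measurable direction here, and this single pair supports no trend for the position. Nothing measured here bears on this exchange or could account for the step.

From the compounds shown here alone, all that has been compared at this oxygen in a single step are two groups of carbon only, with no hydrogen-bond donors, no hydrogen-bond acceptors and no net charge, so the reach of the position remains untested. A group of another kind at the same oxygen, such as a chain ending in an amine or a carboxylic acid, would show whether the read-out in this assay responds to this place at all.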